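One Stereocentre Redrawn, One Number Still Missing

A few compounds are considered here, and "the series" means these few. Any claim that something is new, unique, unknown or untested is made for them only; others in the source may bear on it.

Going by the values given here, the first number in this set comes from a physicochemical assay for acid dissociation, where compound 1 `CN1CC[C@H]2CCC[C@@H](NC(=O)c3ccccc3)[C@H]2C1` gives 9.18. Among the compounds with values here, the only other measured compound, compound 2 `CN1CC[C@H]2CCC[C@@H](OC(=O)c3ccc(Cl)cc3)[C@H]2C1`, gives 8.9. Within the data shown here, these two values lie within the usual scatter of each other, so compound 1 cannot be separated from compound 2 on the numbers so far.

Compound 3 `CN1CC[C@H]2CCC[C@@H](NC(=O)c3ccccc3)[C@@H]2C1` has not yet been measured. Compared with compound 1, it shows this difference: the two compounds have the same atoms and bonds and differ only in configuration as drawn: 1 of 3 stereo elements differ; a stereocentre at a saturated ring carbon is drawn R in compound 1 and S in compound 3. Nothing leaves and nothing enters, and the stereocentre at a saturated ring carbon is drawn R in compound 1 and S in compound 3.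

Among the measured compounds shown here, no pair of measured compounds shows what such a redrawing does in this assay, so there is no direct guide and a shift in either direction remains possible. With the atoms and bonds unchanged, the expectation is no step beyond the scatter. The estimated a number 0.08 log units lower from compound 1 to compound 3 (within the scatter) is small. For compound 3 the expected value is 9.1, with an estimated range from 8.7 to 9.5.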

Compound 3, acid dissociation constant: 8.99
Beside the measured number, compound 3's estimate is 0.11 log units above it, and the stated range covers the measured number.
By their numbers in this assay, from the lowest: compounds 2, 3 and 1 (each within the scatter of the next).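

In this assay, going by these compounds alone, this is the only pair in the set that isolates one redrawn stereocentre, and it gives a number 0.19 log units lower from compound 1 to compound 3 (within the scatter) in this pair of otherwise matching structures. At this saturated ring carbon, the change from R in compound 1 to S in compound 3 therefore stays within the usual scatter of repeated measurements, and this read-out cannot tell the two compounds apart. The comparison is a clean test of configuration at this one centre for a simple reason: the fact that compounds 1 and 3 differ only in the configuration as drawn.

The compounds shown leave open whether redrawing either of the other two stereo elements would also stay within the scatter, as both are drawn the same in compound 1 and compound 3. They also leave open whether the same holds on a different scaffold of substituents, for instance with a longer chain in place of the methyl group on the shared core.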